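The source may report more compounds than this note shows. Statements on the series, on what has been measured and on what is new or still open speak of the compounds shown alone.

Two compounds of this series have numbers in an assay (strain Sprague-Dawley) for displacement of a labelled ligand from metabotropic glutamate receptor 5 (Rattus norvegicus), with a stated time of 60 min; on this read-out higher numbers stand for weaker inhibition and lower numbers for stronger inhibition. Compound 1 `O=S(=O)(c1ccc(F)cc1)c1cnc2cc(F)ccc2c1-c1ccc(Cl)cc1` gives 38.6 nM, while compound 2 `O=S(=O)(c1cc(Cl)cc(Cl)c1)c1cnc2cc(F)ccc2c1-c1cccc(F)c1` gives 10.7 nM, the lower of the two; the gap from compound 2 to compound 1 lies beyond the scatter. Compound 2 and compound 1 differ in two places at once, so neither change can be read on its own. Compound 3 `O=S(=O)(c1cc(Cl)cc(Cl)c1)c1cnc2cc(F)ccc2c1-c1ccc(Cl)cc1` keeps the rest of compound 2 and carries 4-chlorophenyl in place of 3-fluorophenyl on an aromatic carbon. Among the measured compounds shown here, no measured pair isolates this swap, and compound 1 already bears 4-chlorophenyl on the core. The step of a 1.4-fold higher number from compound 2 to compound 3 (0.15 log units; within the scatter) is expected to remain within the scatter. Compound 3 is estimated at 15 nM, within 5 nM to 45 nM.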

Compound 3, inhibition constant: 30.3 nM
For compound 3 the middle estimate is 2.0-fold (0.31 log units) below the measured one; the range from low to high includes it.
By their numbers in this assay, from the lowest: compound 2; then compounds 3 and 1 (each within the scatter of the next).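

With 3,5-dichlorophenyl held on the sulfonyl sulfur, 4-chlorophenyl in place of 3-fluorophenyl on the aromatic carbon opposite the ring nitrogen gives a 2.8-fold higher number from compound 2 to compound 3 (0.45 log units; beyond the scatter), so this position responds modestly to the swap. With 4-chlorophenyl held on the core, 3,5-dichlorophenyl in place of 4-fluorophenyl on the sulfonyl sulfur gives a 1.3-fold lower number from compound 1 to compound 3 (0.11 log units; within the scatter), a step that separates neither compound. No supporting measurement bears on either step.

The halogen and its place change together in this swap, and 3-chlorophenyl or 4-fluorophenyl on the core would separate them. Going by these compounds, how an aminophenyl group would behave at this position remains open.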